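Debenzylation of a chlorinated dihydroindole sulfonamide

The source may hold more compounds than are shown below. What is called first, only, known or untested is meant among the compounds shown, and "the series" means these compounds.

Of the compounds shown here, three sharing one core have been measured in a functional assay on KB cells (Homo sapiens), read by crystal violet staining; a higher number here means a weaker inhibitor, a lower number a stronger inhibitor. Compound 1 `CS(=O)(=O)N1CC(CCl)c2ccc(OCc3ccccc3)cc21` gives 6.32 ug/mL. Compound 2 `CS(=O)(=O)N1CC(CCl)c2ccc(O)cc21` gives 4.24 ug/mL, and the step of a 1.5-fold lower number from compound 1 to compound 2 (0.17 log units; within the scatter) corresponds to the change (hydrogen in place of benzyl on an oxygen on an aromatic ring). Compound 3 `CS(=O)(=O)N1CC(CCl)c2cc(C=O)c(OCc3ccccc3)cc21` gives 3.24 ug/mL; its core differs from that of compound 1 by formyl in place of hydrogen on an aromatic carbon, and the step of a 2.0-fold lower number from compound 1 to compound 3 (0.29 log units; within the scatter) accompanies that difference. Compound 4 `CS(=O)(=O)N1CC(CCl)c2cc(C=O)c(O)cc21` is not yet measured. It arises from compound 3 by hydrogen in place of benzyl on an oxygen on an aromatic ring, the same change that took compound 1 to compound 2, made at an identical place. On that basis the step for compound 4 is expected to be a 1.4-fold lower number from compound 3 to compound 4 (0.13 log units; within the scatter), resting on a 1.5-fold lower number from compound 1 to compound 2 (0.17 log units; within the scatter). Compound 4 is therefore estimated at 2.4 ug/mL, between 1 ug/mL and 6 ug/mL.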

Compound 4, half-maximal inhibitory concentration: 4.83 ug/mL
The estimate for compound 4 lay 2.0-fold (0.30 log units) below the measured number; low and high end bracket the measured number.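

In this assay, hydrogen in place of benzyl gives a 1.5-fold higher number from compound 3 to compound 4 (0.17 log units; within the scatter), and this does not separate from the same change on the core without the formyl group: the same change on two cores in this assay, a 1.5-fold lower number (0.17 log units; within the scatter) from compound 1 to compound 2 and a 1.5-fold higher number (0.17 log units; within the scatter) from compound 3 to compound 4, 2.2-fold (0.35 log units) apart, within the scatter of two such steps

Formyl in place of hydrogen on an aromatic carbon gives a 1.1-fold higher number from compound 2 to compound 4 (0.06 log units; within the scatter), and this likewise does not separate from the earlier step: the same change on two cores in this assay, a 2.0-fold lower number (0.29 log units; within the scatter) from compound 1 to compound 3 and a 1.1-fold higher number (0.06 log units; within the scatter) from compound 2 to compound 4, 2.2-fold (0.35 log units) apart, within the scatter of two such steps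

All these steps lie within the scatter, so the two cores show no measurable difference in how either change carries over, but they also do not show that either change has a real effect or that it transfers reliably.

The compounds shown leave open whether a different group on that oxygen, such as a longer chain, or an amine or a carboxylic acid in place of the formyl group, would move the number beyond the scatter.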